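Swapping the ether chain for an anilino on the coumarin-like core

A few compounds are considered here, and "the series" means these few. Any claim that something is new, unique, unknown or untested is made for them only; others in the source may bear on it.

The series rests on one shared core. Compound 1 `COc1cc(=O)oc2cc(OCc3cccc(F)c3)ccc12` gives 49% in an assay on isolated protein (strain Sprague-Dawley) for inhibition of Amine oxidase [flavin-containing] A (Rattus norvegicus), read by spectrophotometry, with a stated time of 5 min, tested at 10 uM; a lower number here means less inhibition, a higher number more inhibition at the concentration tested (going by the name of the read-out). Compound 2 `CCOc1cc(=O)oc2cc(OCc3cccc(F)c3)ccc12` gives 25%, so that the step of a number 24 percentage points lower from compound 1 to compound 2 (beyond the scatter) lies beyond the scatter. Compound 3 `CC(=O)COc1cc(=O)oc2cc(OCc3cccc(Cl)c3)ccc12` gives 22%, the lowest of the three numbers; it lies within the scatter of compound 2 and beyond the scatter below compound 1.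

The next compound, compound 4 `O=c1cc(Nc2ccccc2)c2ccc(OCc3cccc(Cl)c3)cc2o1`, differs from compound 3 in one place: anilino in place of 2-oxopropoxy on an aromatic carbon. Within the data shown here, the only measured step, from compound 1 to compound 2, concerns a methyl on a chain carbon bound to the ring oxygen and does not touch the kind of change made here, so no measured step bears on it. Compound 4 is therefore expected near the low numbers already seen, with wide uncertainty, at 30% within 5% to 60%. The estimated step for compound 4 is a number 8 percentage points higher from compound 3 to compound 4 (within the scatter), not expected to exceed the scatter.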

Compound 4, a percentage reported as inhibition, at one concentration (the size of the read-out at that concentration, not a potency): 0%
Compound 4: the middle estimate sits 30 percentage points above what was measured; the whole stated range lies above it.
By their numbers in this assay, from the lowest: compound 4; then compounds 3 and 2 (each within the scatter of the next); then compound 1.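

Anilino in place of 2-oxopropoxy on this aromatic carbon, opposite the ring oxygen, gives in this assay a number 22 percentage points lower from compound 3 to compound 4 (beyond the scatter). Compounds 1, 2 and 3 all carry an oxygen-linked chain on this carbon, so they showed only how the number moves among such chains; the present step shows that this position also responds to a change of the whole group, and that with anilino there compound 4 reaches 0%. Nothing measured here explains this loss of inhibition.

The compounds shown leave open whether the loss belongs to the nitrogen link or to the aromatic ring of the anilino group. A methylamino group or a phenoxy group on the same carbon would separate the two, and a benzylamino group would test a longer link to the ring.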